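The source may report more compounds than this note shows. Statements on the series, on what has been measured and on what is new or still open speak of the compounds shown alone.

In an ADME assay on microsomes from liver (Rattus norvegicus) for metabolic stability (a lower number here means that the compound disappears faster, a higher number that the compound lasts longer), compound 1 `CC(C)C(/C=C1\NC(=O)NC1=O)c1ccc(-c2ccc3cccc(F)c3c2)[nH]c1=O` gives 1.46 h as its half-life. Compound 3 `CCC(/C=C1\OC(=O)NC1=O)(CC)c1ccc(-c2ccc3cccc(C(F)(F)F)c3c2)[nH]c1=O` gives 1.09 h as its half-life, a value within the scatter of compound 1, so the two cannot be told apart on these numbers. Compound 2 `CCC(CC)C(/C=C1\OC(=O)NC1=O)c1ccc(-c2ccc3cccc(F)c3c2)[nH]c1=O` is reported as > 3 h and this is a limit of the assay, not a number.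

Compound 4 `C/C(=C1/OC(=O)NC1=O)C(c1ccc(-c2ccc3cccc(F)c3c2)[nH]c1=O)C(C)C` is still unmeasured and differs from compound 1 in one place: a group of 9 heavy atoms (5 carbon, 1 nitrogen, 3 oxygen; one five-membered non-aromatic ring with 2 hetero atoms) in place of a group of 8 heavy atoms (4 carbon, 2 nitrogen, 2 oxygen; one five-membered non-aromatic ring with 2 hetero atoms), on a saturated chain carbon bound to an aromatic carbon and a saturated chain carbon and nothing else. For the measured compounds named here, no measured pair isolates a change of this kind, so the data offer no direct step to go by. Compound 3 carries the same five-membered non-aromatic ring as the entering group and stands at 1.09 h within the scatter of compound 1, so no step beyond the scatter is expected in this assay in either direction. Compound 2 carries that ring too, and its > 3 h is a limit of the assay. The expected change is a 1.2-fold higher number from compound 1 to compound 4 (0.09 log units; within the scatter) and it is estimated to stay within the scatter. For compound 4 the expected half-life is 1.8 h with an estimated range of 0.8 h to 3.5 h in this measurement.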

Compound 4, half-life: > 3 h
Compound 4: a limit, no number; the forecaster's own chance of this, stated with the estimate: 25%; middle value at least 1.6-fold (0.22 log units) from the limit.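

At the saturated chain carbon bound to an aromatic carbon and a saturated chain carbon, the group of 9 heavy atoms (5 carbon, 1 nitrogen, 3 oxygen) in place of the group of 8 heavy atoms (4 carbon, 2 nitrogen, 2 oxygen) gives an at least 2.0-fold higher number from compound 1 to compound 4 (0.31 log units; beyond the scatter) in this assay. This is the only single-place comparison among the compounds shown, so it is the first direct evidence that a change of this kind at this position can move the half-life beyond the scatter. The step gives a lower bound and not a full size: the limit of > 3 h in this assay, at which 2 of the 4 values shown sit.

The compounds shown leave open whether the step follows from the oxygen that replaces a nitrogen in the ring or from the additional carbon in the entering group, as both change together between these two compounds. They also leave open how this assay would respond to a group of another kind at this position, such as an amine or a carboxylic acid.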